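Brominated butenolides: hydroxy on the side chain

A few compounds are considered here, and "the series" means these few. Any claim that something is new, unique, unknown or untested is made for them only; others in the source may bear on it.

Measured so far:
Compound 1, `CCC[C@@H](OC(C)=O)C1=C(Br)C(=C(Br)Br)OC1=O`: in a functional assay on LNCaP cells (Homo sapiens) for cytotoxicity (on this read-out higher numbers stand for an effect only at larger amounts of compound and lower numbers for an effect already at smaller amounts), compound 1 gives 2.1 ug/mL.
Compound 2, `CCCCC1=C(Br)/C(=C/Br)OC1=O`: in this assay compound 2 gives 7.3 ug/mL.

Compound 2 stands at the highest of the two numbers in this assay; its nearest neighbour is compound 1, whose lower number lies beyond the usual scatter. Among the compounds with values here, compound 1 differs from compound 2 in more than one place, so the two values show only that a more substituted analogue of the shared core reaches a lower number; no single step can be read from them.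

Compound 3, `CCC[C@@H](O)C1=C(Br)/C(=C/Br)OC1=O`, is to be measured in this assay. It differs from compound 2 by hydroxy in place of hydrogen on a saturated chain carbon bound to a double-bonded ring carbon and a saturated chain carbon. Within the data shown here, no pair of measured compounds isolates this change, so its size is open. The expectation is a modest step from compound 2 to compound 3, tending toward a lower number, with a fair chance that it stays within the scatter; the step estimated is a 1.6-fold lower number from compound 2 to compound 3 (0.21 log units; within the scatter).

For compound 3 the number expected in this assay is 4.5 ug/mL, with a range from 1.5 ug/mL to 13 ug/mL.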

Compound 3, concentration for half-maximal effect: 0.2 ug/mL
The estimate for compound 3 lay 23-fold (1.35 log units) above the measured number, and the stated range ends above it.
By their numbers in this assay, from the lowest: compound 3; then compound 1; then compound 2.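

Hydroxy in place of hydrogen on a saturated chain carbon bound to a double-bonded ring carbon and a saturated chain carbon gives, in this assay, a 37-fold lower number from compound 2 to compound 3 (1.56 log units; beyond the scatter), a large step and the first in the series that can be read for a single change. This chain carbon is therefore not a silent position: one added hydroxy, a single heavy atom, moves the number well beyond the scatter in this assay. Nothing available here accounts for the size of this step.

The compounds shown leave open whether the step belongs to hydroxy itself or would also appear with another group on this carbon, such as an amine, a methoxy group or a ketone carbonyl. They also leave open whether the opposite configuration at this carbon or a longer chain would keep the low number, and whether the same step would be seen on the core of compound 1.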